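Thiol amides with hindered phenol: dropping the ester

This account rests on a few compounds, and the source may have more. Where it says the series, first, only, none or still open, it means among the compounds named here.

Measured so far in a functional assay, with a stated time of 30 min, tested at 200 uM; on this read-out higher numbers stand for a stronger effect at the one concentration tested and lower numbers for a weaker effect:
- compound 1, `CCOC(=O)C(CS)NC(=O)c1cc(C(C)(C)C)c(O)c(C(C)(C)C)c1`, gives 85%
- compound 2, `O=C(/C=C/c1ccccc1)NCCS`, gives 86%
- compound 3, `CCOC(=O)C(CS)NC(=O)/C=C/c1cc(C(C)(C)C)c(O)c(C(C)(C)C)c1`, gives 96%

Compound 3 gives the top number of the three. Its gap to compound 2 lies within the usual scatter of the read-out, so the two cannot be ranked against each other; its gap to compound 1 lies beyond the scatter. Going by the values given here, no pair among the measured compounds differs in only one place, so no single-change step is on record.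

Compound 4, `CC(C)(C)c1cc(/C=C/C(=O)NCCS)cc(C(C)(C)C)c1O`, differs from compound 3 in one place: hydrogen in place of ethoxycarbonyl on a saturated chain carbon bound to an amide-type nitrogen and a saturated chain carbon. Compound 2 already carries the same unsubstituted chain, and its number sits close to that of compound 3, which gives no sign that the chain substituent drives the read-out. The step from compound 3 to compound 4 is therefore expected to be small and not beyond the scatter, as a number 6 percentage points lower from compound 3 to compound 4 (within the scatter). Compound 4 is estimated at 90%, with a range of 72% to 100%.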

Compound 4, a percentage reported as activity, at one concentration (the size of the read-out at that concentration, not a potency): 92%
Beside the measured number, compound 4's estimate is 2 percentage points below it, and the stated range covers the measured number.
By their numbers in this assay, from the lowest: compounds 1, 2, 4 and 3 (each within the scatter of the next, the first and the last beyond it).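

Going by these compounds alone, on the saturated chain carbon bound to an amide-type nitrogen and a saturated chain carbon, hydrogen in place of ethoxycarbonyl gives the first single-change reading of the series: in this assay, a number 4 percentage points lower from compound 3 to compound 4 (within the scatter). The ethoxycarbonyl group, with its 5 heavy atoms and 2 hydrogen-bond acceptors, can therefore leave this position without a step beyond the scatter, and compound 3 and compound 4 cannot be ranked against each other. No supporting measurement bears on this result.

Open, as far as these compounds go, is how a carboxylic acid, an amine or a longer chain on the same carbon would read in this assay. With a read-out at one concentration, whether compound 3 or compound 4 would give a stronger or weaker effect at any other concentration also stays unresolved.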